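Replacing the Chloroacetamide of Compound 1 with a Nitro Group

The compounds below may be only part of what the source reports. "The series", "measured", "known", "first", "only" and "open" are said of these compounds alone.

Compound 1 `O=C(CCl)Nc1ccc(-c2nc3cc(C(F)(F)F)ccc3[nH]2)cc1` was tested in an ADME assay on MDBK cells (Bos taurus) for cytotoxicity, read by MTT assay, with a stated time of 96 h (on this read-out higher numbers stand for lower toxicity in this test and lower numbers for higher toxicity in this test), where compound 1 gives 17000 nM, the lowest of the three numbers shown. Compound 2 `Cn1c(-c2ccc(N)cc2)nc2cc(C(F)(F)F)ccc21` gives 74000 nM in this assay, and compound 3 `CC(=O)Nc1ccc(-c2nc3cc(Cl)c(Cl)cc3[nH]2)cc1` gives 58000 nM, both beyond the scatter from compound 1. Among the measured compounds shown here, no two measured compounds differ in a single place, so no measured step is available. Compound 4 `O=[N+]([O-])c1ccc(-c2nc3cc(C(F)(F)F)ccc3[nH]2)cc1` has not yet been measured in this assay. nitro in place of ((chloromethyl)carbonyl)amino on an aromatic carbon Because compound 2 gives 74000 nM and compound 3 gives 58000 nM, other groups on this shared core sit well above compound 1, and a modest rise beyond the scatter is expected for compound 4, a 2.4-fold higher number from compound 1 to compound 4 (0.37 log units; beyond the scatter). Compound 4 is therefore expected to give about 40000 nM, within 15000 nM to 100000 nM.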

Compound 4, half-maximal cytotoxic concentration: 6000 nM
Estimate against measurement, compound 4: 6.7-fold (0.82 log units) above, and the stated range ends above it.
By their numbers in this assay, from the lowest: compound 4; then compound 1; then compounds 3 and 2 (each within the scatter of the next).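

Among the compounds shown here, the first measured step at this position, on an aromatic carbon para to a large group, shows that nitro in place of ((chloromethyl)carbonyl)amino gives higher toxicity in this assay, with a 2.8-fold lower number from compound 1 to compound 4 (0.45 log units; beyond the scatter). On this core, then, the ((chloromethyl)carbonyl)amino group is not required for a low number. No measurement shown accounts for this step.

The compounds shown leave open how a nitrile or a carboxylic acid on the same aromatic carbon would read in this assay. They also leave open whether this step would hold on another core.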